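The source may hold more compounds than are shown below. What is called first, only, known or untested is meant among the compounds shown, and "the series" means these compounds.

Series notes. Compound 1 `CO[C@@H]1CC=C2NN(c3c[nH]c4ccccc34)C(=O)CC[C@]2(c2ccccc2)O1` gives 1200 nM in a functional assay on SK-BR-3 cells (Homo sapiens) for cytotoxicity, read by sulforhodamine B assay, with a stated time of 48 h; on this read-out higher numbers stand for weaker inhibition and lower numbers for stronger inhibition. Compound 2 `CO[C@@H]1CC=C2NN(c3cc(Cl)cc(Cl)c3)C(=O)CC[C@]2(c2ccccc2)O1` carries 3,5-dichlorophenyl in place of 1H-indol-3-yl on an amide-type nitrogen in a ring and in this assay compound 2 gives 6350 nM; the step is a 5.3-fold higher number from compound 1 to compound 2 (0.72 log units; beyond the scatter). Compound 3 `CO[C@@H]1CC=C2N(c3c[nH]c4ccccc34)C(=O)C[C@]2(c2ccccc2)O1` is built on a different core; the difference between the two cores is not broken down here. In this assay compound 3 gives 2300 nM, a number within the scatter of that of compound 1. Compound 4 `CO[C@@H]1CC=C2N(c3cc(Cl)cc(Cl)c3)C(=O)C[C@]2(c2ccccc2)O1` has not been measured; it carries 3,5-dichlorophenyl in place of 1H-indol-3-yl on an amide-type nitrogen in a ring. This is the same kind of change as the one seen on the first core, not the same one: there the amide-type nitrogen sits in a seven-membered non-aromatic ring with 2 nitrogen, next to the ring nitrogen, three ring bonds from the ring atom that bears a fused ring and three from the ring atom that bears a phenyl group, whereas in compound 3 it sits in a five-membered non-aromatic ring with 1 nitrogen, two ring bonds from each of those ring atoms. The measured step of a 5.3-fold higher number from compound 1 to compound 2 (0.72 log units; beyond the scatter) is the only basis. For compound 4 a step of similar direction and size is expected, a 4.3-fold higher number from compound 3 to compound 4 (0.64 log units; beyond the scatter). Compound 4 is thus estimated at 10000 nM in this assay, between 4000 nM and 30000 nM.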

Compound 4, half-maximal inhibitory concentration: 6540 nM
Estimate against measurement, compound 4: 1.5-fold (0.18 log units) above, and the stated range covers the measured number.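

In this assay, 3,5-dichlorophenyl in place of 1H-indol-3-yl on the amide-type nitrogen gives a 2.8-fold higher number from compound 3 to compound 4 (0.45 log units; beyond the scatter), so the number rises on this core as well. Set beside the step on the core of compound 1, the new step runs in the same direction and cannot be told apart from it in size: the same change on two cores in this assay, a 5.3-fold higher number (0.72 log units; beyond the scatter) from compound 1 to compound 2 and a 2.8-fold higher number (0.45 log units; beyond the scatter) from compound 3 to compound 4, 1.9-fold (0.27 log units) apart, within the scatter of two such steps. This shows the change carrying over between the two cores shown, in one assay and for one pair of groups; it does not show that the change would carry to any other core, or which feature of either group accounts for the steps.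

The compounds shown leave open how a plain phenyl, a phenyl with a single chlorine, or a phenyl bearing an amine or a carboxylic acid would read on that nitrogen. Also open, as far as these compounds go, is whether the step would hold with another group in place of the phenyl group on the shared ring atom.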